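The source may hold more compounds than are shown below. What is called first, only, known or untested is meant among the compounds shown, and "the series" means these compounds.

Measured so far in a functional assay on CHO cells for agonist activity at muscarinic acetylcholine receptor M5 (Homo sapiens), read by calcium flux; on this read-out higher numbers stand for an effect only at larger amounts of compound and lower numbers for an effect already at smaller amounts:
- compound 1 `O=C1C(=O)N(Cc2ccc(-c3ccc(F)nc3)cc2)c2ccc(OC(F)(F)F)cc21`: 3600 nM
- compound 2 `Cn1cc(-c2ccc(CN3C(=O)C(=O)c4cc(OC(F)(F)F)ccc43)cc2)cn1`: 3300 nM

Within the data shown here, compound 2 stands at the lower of the two numbers, but the only step that reaches it, a 1.1-fold lower number from compound 1 to compound 2 (0.04 log units; within the scatter), lies within the scatter, so compound 1 and compound 2 cannot be separated on this read-out.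

Compound 3 `O=C1C(=O)N(Cc2ccc(Oc3ccccc3)cc2)c2ccc(OC(F)(F)F)cc21` is the next change at the same place on the ring: phenoxy in place of 1-methyl-1H-pyrazol-4-yl on an aromatic carbon. Among the measured compounds shown here, the one measured step that bears on it is the exchange of one aromatic group for another at this carbon, which left the number essentially unchanged. For the measured compounds named here, the present change is of a different kind, since an oxygen-linked ring enters rather than a directly attached heteroaromatic ring, and there is no measured precedent for that. On the flat behaviour seen so far, the step is expected to be a 1.1-fold higher number from compound 2 to compound 3 (0.03 log units; within the scatter), with the range widened to cover the lack of a precedent. Compound 3 is therefore expected to give about 3500 nM in this assay, between 1200 nM and 10000 nM.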

Compound 3, half-maximal effective concentration: 1900 nM
Beside the measured number, compound 3's estimate is 1.8-fold (0.27 log units) above it; low and high end bracket the measured number.
By their numbers in this assay, from the lowest: compounds 3, 2 and 1 (each within the scatter of the next).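

Phenoxy is the first group at this carbon joined through oxygen and the first with a ring of carbon only, and the number still stays within the scatter of both earlier compounds in this assay (a 1.7-fold lower number from compound 2 to compound 3 (0.24 log units; within the scatter); a 1.9-fold lower number from compound 1 to compound 3 (0.28 log units; within the scatter)). Compounds 1, 2 and 3 therefore cannot be separated on this read-out, so neither the change of linkage nor the loss of ring nitrogen has a resolved effect in this set, although both steps are larger than the earlier step between the two directly attached heteroaromatic rings, which also lies within the scatter. Nothing available here offers a reason for the similar numbers of these three groups.

As far as these compounds go, all three compounds carry an aromatic ring at this position, so it remains open whether a non-aromatic group such as a morpholine, a carboxylic acid or a longer alkyl chain would move the number beyond the scatter. They also share the rest of the core, including the trifluoromethoxy group, so the compounds shown say nothing about changes elsewhere on the molecule.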